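The source may hold more compounds than are shown below. What is called first, only, known or untested is meant among the compounds shown, and "the series" means these compounds.

Three compounds of this series have a result in hand. Compound 1 `Oc1ccccc1CNc1ccc(N2CCCCC2)cc1` is reported as "not active" (no number reported) in a functional assay on Jurkat cells (Homo sapiens) for activation, with a stated time of 24 h (a lower number here means that less compound is needed, a higher number that more compound is needed for the effect), with no single number behind it. Compound 2 `N#Cc1ccc(-c2ccc(NCc3ccccc3O)cc2)cc1` stands in the same position: in this assay compound 2 is likewise given as "not active" (no number reported), so no number is attached to it, and one further entry of the set, that of compound 1, also carries no single number. Among the compounds with values here, the only compound with a figure is compound 3 `Oc1ccccc1CNc1ccc(-c2cccc(Cl)c2)cc1`, which in this assay gives 6200 nM. Within the data shown here, nothing more than these three results is available, and no pair among them differs in a single place, so no measured step can be drawn.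

The next compound, compound 4 `CC(C)Oc1ccc(-c2ccc(NCc3ccccc3O)cc2)cc1`, follows compound 2 with one change: isopropoxy in place of cyano on an aromatic carbon The cyano leaves and an isopropoxy enters on an aromatic carbon of the shared core. Among the measured compounds shown here, since compound 2 has no number, no step can be computed. On what is known, a result near that of compound 3 or weaker is expected for compound 4, with a real chance that no number is reported at all. Compound 4 is estimated at 9000 nM, with a range from 2500 nM to 30000 nM.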

Compound 4, half-maximal effective concentration: 5940 nM
Beside the measured number, compound 4's estimate is 1.5-fold (0.18 log units) above it, within the range that was stated.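

Compound 2 carries no single number in this assay and compound 4 gives 5940 nM there, so no step can be read between compound 2 and compound 4. No measurement at hand bears on this result. The compounds shown leave open what a single change on the shared core does in this assay.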